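Swapping Trifluoromethyl for Dimethylaminomethyl on the Shared Core

The compounds below may be only part of what the source reports. "The series", "measured", "known", "first", "only" and "open" are said of these compounds alone.

Compound 1 `Cc1nc2ccccc2n1CC(=O)N/N=C/c1c(O)ccc2ccccc12` and compound 2 `O=C(CCn1c(C(F)(F)F)nc2ccccc21)N/N=C/c1c(O)ccc2ccccc12` share a core and differ both in the group carried on the five-membered ring and in the chain that joins it to the hydrazone. In a physicochemical assay for solubility, read by fluorescence and spectrophotometry (a higher number here means a more soluble compound, a lower number a less soluble compound), compound 1 gives 20000 nM, and compound 2 gives 30000 nM. Compound 2 thus shows the higher of the two numbers, but its gap to compound 1 lies within the scatter of repeated measurements, so the two cannot be told apart. Compound 3 `CN(C)Cc1nc2ccccc2n1CCC(=O)N/N=C/c1c(O)ccc2ccccc12` keeps the chain of compound 2 and changes one group: (dimethylamino)methyl in place of trifluoromethyl on an aromatic carbon. Among the measured compounds shown here, no pair of measured compounds shows this change, so no step is on record for it. In this assay compound 3 is expected to move upward beyond the scatter, a step of a 2.3-fold higher number from compound 2 to compound 3 (0.37 log units; beyond the scatter). Compound 3 is estimated to give 70000 nM, within a range from 25000 nM to 200000 nM.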

Compound 3, solubility: 90000 nM
Compound 3: middle estimate off by 1.3-fold (0.11 log units), on the low side; the measured number falls inside the stated range.
By their numbers in this assay, from the lowest: compounds 1 and 2 (each within the scatter of the next); then compound 3.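

In this assay, (dimethylamino)methyl in place of trifluoromethyl on an aromatic carbon gives a 3.0-fold higher number from compound 2 to compound 3 (0.48 log units; beyond the scatter), which lies beyond the scatter of repeated measurements. Compound 1 and compound 2 differ in two places at once and cannot be told apart, whereas compound 2 and compound 3 share the same chain and differ in this one group. This position on the five-membered ring can therefore change the read-out, and the change from trifluoromethyl to (dimethylamino)methyl raises it. Nothing measured here gives a reason for the rise. With the chain of compound 3 kept, a plain methyl, an aminomethyl or a carboxylic acid at this carbon would show how much of the step depends on the entering group. As far as these compounds go, it also remains open whether (dimethylamino)methyl gives a similar step on the chain of compound 1.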